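Piperazine tail variation in the imidazole amide series

This account rests on a few compounds, and the source may have more. Where it says the series, first, only, none or still open, it means among the compounds named here.

Measured so far:
compound 1 `Cn1c(-c2ccc(NC(=O)CSc3nc4cc(Cl)ccc4o3)cc2)nc(-c2ccccc2)c1-c1ccccc1`, 27.7%
compound 2 `Cc1nnc(SCC(=O)Nc2ccc(-c3nc(-c4ccccc4)c(-c4ccccc4)n3C)cc2)s1`, 67.8%
compound 3 `CN1CCN(CC(=O)Nc2ccc(-c3nc(-c4ccccc4)c(-c4ccccc4)n3C)cc2)CC1`, 28.6%

Three compounds share the core with the amide link; they differ only in the group on the saturated chain carbon bound to the carbonyl carbon. In a functional assay on MCF7 cells (Homo sapiens) for cytotoxicity, read by MTT assay, with a stated time of 24 h, tested at 6.4 ug/mL (on this read-out higher numbers stand for a stronger effect at the one concentration tested and lower numbers for a weaker effect), compound 3 gives 28.6%, which is the second highest of the three numbers; its nearest neighbour is compound 1, at 27.7%, and the two lie within the scatter of each other, so no order between them can be stated. Among the measured compounds shown here, compound 2 stands apart: a number 39.2 percentage points lower from compound 2 to compound 3 (beyond the scatter) and a number 40.1 percentage points higher from compound 1 to compound 2 (beyond the scatter) are the only steps beyond the scatter, both tied to the thiadiazolyl-sulfanyl tail. The step of a number 0.9 percentage points higher from compound 1 to compound 3 (within the scatter) shows that the piperazinyl tail and the benzoxazolyl-sulfanyl tail give equal numbers.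

Compound 4 `COc1ccc(CN2CCN(CC(=O)Nc3ccc(-c4nc(-c5ccccc5)c(-c5ccccc5)n4C)cc3)CC2)cc1` keeps the piperazinyl tail of compound 3 and changes it: 4-methoxyphenyl in place of hydrogen on a saturated chain carbon bound to an amine nitrogen in a ring. For the measured compounds named here, none of the measured steps touches this position; the steps available all swap the whole tail, so they give no direct guide to the size of this change. The expectation is therefore a step of modest size in this assay, in the direction a number 7.4 percentage points higher from compound 3 to compound 4 (within the scatter), with wide uncertainty. Compound 4 is estimated at 36%, within a range from 15% to 60%.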

Compound 4, a percentage reported as activity, at one concentration (the size of the read-out at that concentration, not a potency): 29%
Compound 4: the middle estimate sits 7 percentage points above what was measured, and the stated range covers the measured number.
By their numbers in this assay, from the lowest: compounds 1, 3 and 4 (each within the scatter of the next); then compound 2.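

Among the compounds shown here, until now no step touched the position on a saturated chain carbon bound to an amine nitrogen in a ring, and the first reading there, in this assay, is a number 0.4 percentage points higher from compound 3 to compound 4 (within the scatter). The change from methyl to 4-methoxybenzyl, which brings in 8 heavy atoms and one six-membered aromatic ring, therefore gives a number that cannot be told apart from that of the parent, so at the one concentration tested this read-out tolerates this large group at this place without a detectable difference. No measurement bearing on this result is available to explain it.

One substituent at one position cannot show whether this place is insensitive in general: an unsubstituted benzyl, a 4-fluorobenzyl, a carboxylic acid or a longer alkyl chain on the same ring nitrogen could still move the number beyond the scatter. Also open, on these data alone, is whether compound 3 and compound 4 would remain indistinguishable at other concentrations, since a single-concentration read-out gives no potency.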